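Removing a second ring hydroxy from a trisphosphate inhibitor

The compounds below may be only part of what the source reports. "The series", "measured", "known", "first", "only" and "open" are said of these compounds alone.

Measured so far:
Compound 1, `O=P(O)(O)OC1[C@H](O)CC(OP(=O)(O)O)[C@H](OP(=O)(O)O)[C@@H]1O`, 11500 nM
Compound 2, `O=P(O)(O)OC1CCC(OP(=O)(O)O)[C@H](OP(=O)(O)O)[C@@H]1O`, 16500 nM

Both compounds were tested in an assay for inhibition of inositol polyphosphate-5-phosphatase A (Homo sapiens); a higher number here means a weaker inhibitor, a lower number a stronger inhibitor. Compound 1 and compound 2 differ by one change on the shared core: a 1.4-fold higher number from compound 1 to compound 2 (0.16 log units; within the scatter). Of the two numbers, compound 2 gives the higher one, but its step from compound 1 lies within the scatter, so the two cannot be ranked against each other on these data.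

Compound 3, `O=P(O)(O)OC1CCC(OP(=O)(O)O)[C@H](OP(=O)(O)O)C1`, has not yet been measured. It differs from compound 2 in one place: hydrogen in place of hydroxy on a saturated ring carbon. This is the same kind of change, hydrogen in place of hydroxy on a saturated ring carbon, that separated compound 1 from compound 2. That earlier step was small and within the scatter, so the step of a 1.3-fold higher number from compound 2 to compound 3 (0.12 log units; within the scatter) is expected to be small as well, with at most a slight shift toward a higher number, which a single measurement may not resolve. On that basis compound 3 is estimated to give 22000 nM in this assay, within a range of 9000 nM to 60000 nM.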

Compound 3, inhibition constant: 81400 nM
Compound 3: middle estimate off by 3.7-fold (0.57 log units), on the low side; measured number outside the range, above it.
By their numbers in this assay, from the lowest: compounds 1 and 2 (each within the scatter of the next); then compound 3.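

In this assay, replacing hydroxy with hydrogen does not have one fixed effect on the shared core: the earlier swap gave a 1.4-fold higher number from compound 1 to compound 2 (0.16 log units; within the scatter), whereas the swap at this position gave a 4.9-fold higher number from compound 2 to compound 3 (0.69 log units; beyond the scatter). Among these compounds, this position is a saturated ring carbon next to two ring atoms that each bear a group of 5 heavy atoms, and the hydroxy here is the first of the two whose replacement produces a step that can be read as real, though it is a modest one. Nothing available explains why this hydroxy counts for more than the earlier one.

The swap at this position was seen only on a core that had already lost the other hydroxy, so the compounds shown leave open how large the step would be if that other hydroxy were still present. They also leave open whether an amine, a fluorine atom or a methoxy group on this ring carbon would give a number closer to that of compound 2 or to that of compound 3.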